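The source may report more compounds than this note shows. Statements on the series, on what has been measured and on what is new or still open speak of the compounds shown alone.

Measured so far:
Compound 2, `C=CCOc1c(Cl)cc(Cl)cc1C(=O)c1cccnc1` — 34000 nM
Compound 3, `C=CCOc1ccc(Cl)cc1C(=O)c1cccnc1` — 75000 nM
Compound 1, `C=CCOc1cc(Br)ccc1C(=O)c1cccnc1` — the value is a limit of the assay: > 100000 nM

In a functional assay on HeLa cells (Homo sapiens) for cytotoxicity, read by sulforhodamine B assay, with a stated time of 48 h (on this read-out lower numbers stand for stronger inhibition and higher numbers for weaker inhibition), compound 2 gives 34000 nM and stands lowest of the two numbers shown; compound 3 gives 75000 nM, the nearest number. For compound 1 the result is a limit of the assay only, (the limit of > 100000 nM in this assay, at which 1 of the 3 values shown sits), and no number is available for it.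

Among the compounds with values here, the one measured step, a 2.2-fold higher number from compound 2 to compound 3 (0.34 log units; beyond the scatter), is the exchange of hydrogen in place of chloro on an aromatic carbon; it is modest, though beyond the scatter.

Compound 4, `O=C(c1cccnc1)c1cc(Cl)cc(Cl)c1O`, is the next entry. Relative to compound 2 the change is hydrogen in place of allyl on an oxygen on an aromatic ring. Within the data shown here, no measured step touches this oxygen: the step from compound 2 to compound 3 alters a ring substituent and leaves the allyloxy untouched, so it gives no direct guide to the size or direction of this exchange. In the absence of a comparable step, the expectation for compound 4 in this assay is a step of a 1.2-fold higher number from compound 2 to compound 4 (0.07 log units; within the scatter) of no clear direction, most likely within the scatter, with a wide margin.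

Compound 4 is therefore estimated at 40000 nM, with a range from 12000 nM to 100000 nM.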

Compound 4, half-maximal inhibitory concentration: > 100000 nM
Compound 4 was reported as a limit (the forecaster's own chance of this, stated with the estimate: 25%); at least 2.5-fold (0.39 log units) between middle value and limit.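

Within the data shown here, this is the first reading at the oxygen itself, as the earlier compounds varied only ring substituents and all kept the allyloxy. In this assay, hydrogen in place of allyl on this oxygen gives an at least 2.9-fold higher number from compound 2 to compound 4 (0.46 log units; beyond the scatter), so the allyl cannot be removed here without a loss of inhibition beyond the scatter, and the free hydroxy does not retain the reading of the allyl ether. The result for compound 4 is a limit and not a number, so the step gives only a minimum size, and compound 4 cannot be ranked against compound 1, whose result is also a limit: the limit of > 100000 nM in this assay, at which 2 of the 4 values shown sit.

As far as these compounds go, whether the allyl acts through its double bond or simply as a carbon chain on this oxygen stays open, and a saturated propyl, a methyl or a longer chain such as butyl in the same place would separate these readings. Also open, from the compounds shown here alone, is whether the same exchange carries the same penalty on the single-chloro core of compound 3, where a hydroxy counterpart would give a second reading of this change.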